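Swapping a triple bond for a double bond

The source may hold more compounds than are shown below. What is called first, only, known or untested is meant among the compounds shown, and "the series" means these compounds.

Measured in a functional assay on A-431 cells (Homo sapiens) for inhibition; on this read-out lower numbers stand for stronger inhibition and higher numbers for weaker inhibition:
Compound 1 `CCCCCC#C[C@@]1(C)O[C@@H]2OC(=O)N(C(=O)CCl)[C@@H]2CC1=O`: 47000 nM
Compound 2 `C[C@]1(C#CCCCCc2ccccc2)O[C@@H]2OC(=O)N(C(=O)CCl)[C@@H]2CC1=O`: 56000 nM

Among the compounds with values here, with only two compounds measured, compound 1 has just one neighbour on this scale. The step between them is a 1.2-fold higher number from compound 1 to compound 2 (0.08 log units; within the scatter), so the two values cannot be told apart.

Compound 3 `CCCCC/C=C/[C@@]1(C)O[C@@H]2OC(=O)N(C(=O)CCl)[C@@H]2CC1=O` keeps the core of compound 1 and changes one group: hept-1-en-1-yl in place of hept-1-yn-1-yl on a saturated ring carbon. The triple bond becomes a double bond, while the chain keeps its seven carbons.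

Within the data shown here, the one measured step, phenyl in place of methyl on a saturated chain carbon, leaves the triple bond untouched. Among the measured compounds shown here, it shows that one change within this chain stayed inside the scatter, but no measured pair compares a triple bond with a double bond. The evidence is therefore indirect, and the range must stay wide. No shift beyond the scatter is expected in this assay, in either direction, and the expected step is a 1.0-fold lower number from compound 1 to compound 3 (0.02 log units; within the scatter). For compound 3 the estimated value is 45000 nM, with an expected range from 18000 nM to 110000 nM.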

Compound 3, half-maximal inhibitory concentration: 81000 nM
Beside the measured number, compound 3's estimate is 1.8-fold (0.26 log units) below it; the range from low to high includes it.
By their numbers in this assay, from the lowest: compounds 1, 2 and 3 (each within the scatter of the next).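

Within the data shown here, this is the first direct comparison of a triple bond with a double bond on this saturated ring carbon, and in this assay it gives a 1.7-fold higher number from compound 1 to compound 3 (0.24 log units; within the scatter). Hept-1-en-1-yl and hept-1-yn-1-yl therefore cannot be told apart on this read-out, so for this one chain the double bond can take the place of the triple bond with no difference that the measurement can resolve. Nothing available helps to explain this result.

On these data alone, it remains open whether a fully saturated heptyl chain, a shorter chain such as propyl, or a chain ending in an amine or a carboxylic acid on this saturated ring carbon would also stay within the scatter of compound 1, which gives 47000 nM in this assay. As far as these compounds go, it is equally open whether the same swap of triple bond for double bond would read the same on the phenyl-bearing chain of compound 2.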